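The source may hold more compounds than are shown below. What is called first, only, known or untested is meant among the compounds shown, and "the series" means these compounds.

Measured compounds:
compound 1, `CCN(CC)C(=O)CC1CCc2cc(OC)c(OC)cc21`, 37.7%
compound 2, `COc1cc2c(cc1OC)C(CC(=O)NC(C)C)CC2`, 30.4%
compound 3, `COc1cc2c(cc1OC)C(CC(=O)NC1CCCCC1)CC2`, 49.3%

All three share one core and differ only in the group attached to the carbonyl carbon. In a functional assay on the whole organism (strain Wistar) for inhibition, with Rattus norvegicus as the target, read by paw edema, with stated times of 60 min and 3 h, at a dose of 100 mg/kg by the oral route (a higher number here means more inhibition at the dose given (going by the name of the read-out), a lower number less inhibition), compound 3 gives 49.3%, the highest of the three numbers: a number 11.6 percentage points higher from compound 1 to compound 3 (beyond the scatter) and a number 18.9 percentage points higher from compound 2 to compound 3 (beyond the scatter), both beyond the scatter, while a number 7.3 percentage points lower from compound 1 to compound 2 (within the scatter) stays within it. Compound 4, `COc1cc2c(cc1OC)C(CC(=O)N1CCOCC1)CC2`, has not yet been measured in this assay. Its change from compound 3 is morpholin-4-yl in place of cyclohexylamino on a carbonyl carbon. The group that leaves carries a hydrogen-bond donor; the group that enters has none and brings one hydrogen-bond acceptor. For the measured compounds named here, the step that bears most on this is a number 11.6 percentage points higher from compound 1 to compound 3 (beyond the scatter), because compound 1 gives 37.7% with a group that, like the one entering in compound 4, has no hydrogen-bond donor. The change from compound 3 to compound 4 is therefore expected to give back a good part of that gain, a modest step downward: a number 13.3 percentage points lower from compound 3 to compound 4 (beyond the scatter). Compound 4 is estimated at 36%, with a range from 22% to 50%.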

Compound 4, a percentage reported as inhibition, in the whole organism at one dose (the size of the read-out at that dose, not a potency): 19.6%
For compound 4 the middle estimate is 16.4 percentage points above the measured one, and the stated range ends above it.
By their numbers in this assay, from the lowest: compound 4; then compounds 2 and 1 (each within the scatter of the next); then compound 3.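

In this assay morpholin-4-yl stands lowest of the four groups on this carbonyl carbon: there is a number 29.7 percentage points lower from compound 3 to compound 4 (beyond the scatter) and also a number 10.8 percentage points lower from compound 2 to compound 4 (beyond the scatter) and a number 18.1 percentage points lower from compound 1 to compound 4 (beyond the scatter) in the same direction. A six-membered ring alone therefore does not secure a high number here, for cyclohexylamino and morpholin-4-yl each bring such a ring, yet they sit at opposite ends of the series. Losing the hydrogen-bond donor is not the whole story either: diethylamino in compound 1 also has none and still stands above compound 4, while compound 2 has one and stays within the scatter of compound 1. No measurement shown gives a reason for this order. The compounds shown leave open whether the drop goes with the ring oxygen of morpholin-4-yl or with the loss of the amide hydrogen. Piperidin-1-yl, a ring of the same size with carbon in place of that oxygen, and tetrahydropyran-4-ylamino, which keeps both the ring oxygen and the amide hydrogen, would pull these two apart.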